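A few compounds are considered here, and "the series" means these few. Any claim that something is new, unique, unknown or untested is made for them only; others in the source may bear on it.

Compound 2 `Cc1ccc2[nH]c(=O)c(CN(CCCO)Cc3ccc(C(C)(C)C)cc3)cc2c1` is one of three compounds already measured in a toxicity assay on MDCK cells (Canis lupus familiaris) for cytotoxicity, read by crystal violet staining, with a stated time of 48 h; on this read-out higher numbers stand for lower toxicity in this test and lower numbers for higher toxicity in this test. In this assay compound 2 gives > 10000 nM, which is a limit of the assay rather than a number. Compound 3 `CCc1ccc2[nH]c(=O)c(CN(CCCO)Cc3ccc(C(C)(C)C)cc3)cc2c1` in this assay likewise gives > 10000 nM, again only a limit. Compound 1 `CCc1ccc2[nH]c(=O)c(CN(Cc3ccc(C(C)(C)C)cc3)Cc3ccc(F)c(F)c3)cc2c1` in this assay gives > 33000 nM, also a limit. Compound 2 thus stands at the same limit as compound 3 (the limit of > 10000 nM in this assay, at which 2 of the 3 values shown sit), while compound 1 sits at a different limit (the limit of > 33000 nM in this assay, at which 1 of the 3 values shown sits). The change to compound 4 `Cc1ccc2[nH]c(=O)c(CN(Cc3ccc(C(C)(C)C)cc3)C(C)c3ccc(F)cc3)cc2c1` is 1-(4-fluorophenyl)ethyl in place of 3-hydroxypropyl on an amine nitrogen. Among the compounds with values here, two measured steps bear on it, a step that the two limits leave unreadable from compound 2 to compound 3 and a step that the two limits leave unreadable from compound 1 to compound 3, but neither has a readable size, since all values are limits. No step beyond the scatter can be expected in either direction. Compound 4 is estimated at 30000 nM, between 8000 nM and 100000 nM, an expected step that the limit leaves unreadable from compound 2 to compound 4 that most likely again ends as a limit.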

Compound 4, half-maximal cytotoxic concentration: > 33000 nM
Compound 4 was reported as a limit (the forecaster's own chance of this, stated with the estimate: 75%); at least 1.1-fold (0.04 log units) between middle value and limit.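

In this assay, within the data shown here, compound 2 and compound 4 are each reported only as a limit, so no step between them can be read. The compounds shown leave open whether 1-(4-fluorophenyl)ethyl in place of 3-hydroxypropyl changes the half-maximal cytotoxic concentration at all.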